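A few compounds are considered here, and "the series" means these few. Any claim that something is new, unique, unknown or untested is made for them only; others in the source may bear on it.

Measured compounds and their values in a physicochemical assay for lipophilicity; a higher number here means a more lipophilic compound, a lower number a more polar compound:

compound 1 `N=C(N)Nc1cccc(C(=O)NNC(=O)NC(CC(=O)O)c2ccccc2)c1` gives 0.7
compound 2 `N=C(N)Nc1cccc(C(=O)NNC(=O)NC(CC(=O)O)c2ccc(F)cc2)c1` gives 0.86
compound 3 `O=C(O)CC(NC(=O)NNC(=O)CCCCNc1ccccn1)c1ccccc1` gives 1.64

Compound 1 and compound 2 share one core and differ only in the change (fluoro in place of hydrogen on an aromatic carbon). The step in this assay from that change is a number 0.16 log units higher from compound 1 to compound 2 (within the scatter), so the two values cannot be told apart by this measurement.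

Compound 3 carries a different core; how the core of compound 3 differs from the core of compound 1 is not broken down here. Its value stands beyond the scatter above both compound 1 and compound 2.

Compound 4 `O=C(O)CC(NC(=O)NNC(=O)CCCCNc1ccccn1)c1ccc(F)cc1` is not yet measured. It differs from compound 3 by fluoro in place of hydrogen on an aromatic carbon, the same change as that from compound 1 to compound 2, at a place described in identical words. The expected step in this assay from compound 3 to compound 4 is therefore put beside the measured one: a number 0.16 log units higher from compound 3 to compound 4 (within the scatter), which rests on the step of a number 0.16 log units higher from compound 1 to compound 2 (within the scatter) and on the assumption that the change carries over unaltered onto the core of compound 3. On that basis compound 4 is expected to give 1.8 in this assay, with a range from 1.5 to 2.1. Whether the new core alters the size of the step is not known from the compounds at hand.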

Compound 4, partition coefficient: 1.8
Beside the measured number, compound 4's estimate shows no gap at the digits printed; the range from low to high includes it.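

In this assay, phenyl to 4-fluorophenyl on the core of compound 3 gives a number 0.16 log units higher from compound 3 to compound 4 (within the scatter) and on the core of compound 1 gives a number 0.16 log units higher from compound 1 to compound 2 (within the scatter) as its counterpart, so the two steps match at the digits printed and this change carries from one core to the other in this pair of pairs. What that shows is limited: each step lies within the scatter, so neither pair separates the fluoro compound from its hydrogen parent, and the agreement is between two steps too small to be resolved, not proof that a step of real size would carry over in the same way, nor a rule for any core beyond these two. No measurement at hand gives a reason for the size of either step.

Open, going by these compounds, is whether a group such as chloro, methoxy or trifluoromethyl, entering at the same place on the aromatic ring, would give a step beyond the scatter and whether that step would then match on both cores. Also open, on these data alone, is whether the match would hold with a methyl ester in place of the carboxylic acid, or with a longer chain in the core of compound 3.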